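Dimethylamino to methyl swap carried to a second compound

The compounds below may be only part of what the source reports. "The series", "measured", "known", "first", "only" and "open" are said of these compounds alone.

Compound 1 `COc1cc(-c2nc(N(C)C)sc2-c2ccc3ccccc3c2)cc(OC)c1OC` and compound 2 `COc1cc(-c2nc(N(C)C)sc2-c2ccc(C)cc2)cc(OC)c1OC` share one core and differ by 4-methylphenyl in place of naphthalen-2-yl on an aromatic carbon. In a functional assay on HeLa cells (Homo sapiens) for antiproliferative activity, read by MTT assay, with a stated time of 72 h (a higher number here means a weaker inhibitor, a lower number a stronger inhibitor), compound 1 gives 1400 nM, and compound 2 gives 4140 nM, a step of a 3.0-fold higher number from compound 1 to compound 2 (0.47 log units; beyond the scatter). Compound 3 `COc1cc(-c2nc(C)sc2-c2ccc3ccccc3c2)cc(OC)c1OC` carries the change methyl in place of dimethylamino on an aromatic carbon relative to compound 1; in this assay compound 3 gives 82.1 nM, which is a step of a 17-fold lower number from compound 1 to compound 3 (1.23 log units; beyond the scatter). Compound 4 `COc1cc(-c2nc(C)sc2-c2ccc(C)cc2)cc(OC)c1OC` is not yet measured and differs from compound 2 by methyl in place of dimethylamino on an aromatic carbon. The two swaps are the same kind of change, not the same: around the place, the ring atom two ring bonds away bears a naphthalen-2-yl group in the first case and a 4-methylphenyl group in the second. Of the three measured compounds, compound 2 stands highest in this assay. Among the compounds with values here, only one measured instance of this swap exists, so any transfer rests on a single step. The step from compound 2 to compound 4 is expected to be about a 14-fold lower number from compound 2 to compound 4 (1.14 log units; beyond the scatter), set beside the earlier 17-fold lower number from compound 1 to compound 3 (1.23 log units; beyond the scatter), because a 17-fold lower number from compound 1 to compound 3 (1.23 log units; beyond the scatter) was large and beyond the scatter. Compound 4 is therefore estimated at 300 nM in this assay, with a range of 100 nM to 1000 nM.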

Compound 4, half-maximal inhibitory concentration: 1100 nM
Beside the measured number, compound 4's estimate is 3.7-fold (0.56 log units) below it; the measured number lies above the stated range.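

In this assay methyl in place of dimethylamino again lowers the number on the core bearing the 4-methylphenyl group, with a 3.8-fold lower number from compound 2 to compound 4 (0.58 log units; beyond the scatter) on this second core, so the direction of the change is the same on both cores shown. The size of the step does not carry over between the two cores: the same change on two cores in this assay, a 17-fold lower number (1.23 log units; beyond the scatter) from compound 1 to compound 3 and a 3.8-fold lower number (0.58 log units; beyond the scatter) from compound 2 to compound 4, 4.5-fold (0.66 log units) apart, beyond the scatter of two such steps. Two pairs show only that the direction held in these two cases; they establish no rule for the series, and they do not explain why the steps differ in size.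

The compounds shown leave open how a methylamino or an ethyl group would compare with methyl and dimethylamino on either core. Also open, as far as these compounds go, is whether the direction and size of the swap would hold with a 4-chlorophenyl group in place of the 4-methylphenyl group, which would give a third core to set beside these two.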